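Chloro on the naphthalene sulfonamide of compound 2

The compounds below may be only part of what the source reports. "The series", "measured", "known", "first", "only" and "open" are said of these compounds alone.

Two compounds of this series carry numbers in an assay on isolated protein for inhibition of Apoptosis regulator Bcl-2 (Homo sapiens), read by fluorescence polarization, with a stated time of 60 min; on this read-out lower numbers stand for stronger inhibition and higher numbers for weaker inhibition. Compound 1 `CCCCc1c(-c2ccc(C(=O)NS(=O)(=O)c3ccc4ccccc4c3)cc2C(=O)N2Cc3ccccc3C[C@H]2CN)c(CO)nn1-c1ccccc1` gives 24 nM in this assay. Compound 2 `CCCCN(CCCC)c1nccc(-c2ccc(C(=O)NS(=O)(=O)c3ccc4ccccc4c3)cc2C(=O)N2CCc3ccccc3C2)n1` gives 700 nM in this assay; it stands highest of the two numbers, and compound 1 lies well beyond the scatter below it. The two differ in several places at once, so their gap is not tied to any single change.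

Compound 3 `CCCCN(CCCC)c1nccc(-c2ccc(C(=O)NS(=O)(=O)c3ccc4cccc(Cl)c4c3)cc2C(=O)N2CCc3ccccc3C2)n1` is the next member, not yet measured. It differs from compound 2 by chloro in place of hydrogen on an aromatic carbon, which read one bond further out is naphthalen-2-yl going to 8-chloronaphthalen-2-yl. Within the data shown here, no measured pair shows this change, so nothing sets its size or direction. The expectation is a small step from compound 2 to compound 3 of a 1.4-fold lower number from compound 2 to compound 3 (0.15 log units; within the scatter), at most modestly beyond the scatter. Compound 3 is estimated at 500 nM, within 150 nM to 1500 nM.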

Compound 3, half-maximal inhibitory concentration: 120 nM
Compound 3: middle estimate off by 4.2-fold (0.62 log units), on the high side, outside the stated range (below it).
By their numbers in this assay, from the lowest: compound 1; then compound 3; then compound 2.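

Among these compounds, replacing hydrogen with chloro, naphthalen-2-yl going to 8-chloronaphthalen-2-yl, gives in this assay a 5.8-fold lower number from compound 2 to compound 3 (0.77 log units; beyond the scatter), the first step that can be tied to a single place. The number therefore responds to one added chlorine on this aromatic carbon of the naphthalene, which the earlier pair, differing in several places at once, could not show. No measurement given here accounts for this step.

From the compounds shown here alone, whether bromo, methyl or methoxy at this same carbon would give a step of similar size and direction remains open, as does the effect of chloro on other carbons of the naphthalene. Also open, going by these compounds, is whether the chloro step carries over to the core of compound 1.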